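Methoxy in place of fluoro on the terminal ring

This account rests on a few compounds, and the source may have more. Where it says the series, first, only, none or still open, it means among the compounds named here.

compound 1 `CN(C)C(=O)c1cnc(C(=O)CCCCCCc2ccccc2)o1` — > 10000 nM
compound 2 `O=C(CCCCCCc1ccccc1)c1ncc(-c2ccc(F)cc2)o1` — > 10000 nM

In an assay on HEK-293T cells for inhibition of diacylglycerol lipase-alpha (Homo sapiens), read by colorimetric assay (a lower number here means a stronger inhibitor, a higher number a weaker inhibitor), compound 1 gives > 10000 nM, which is a limit of the assay. Compound 2 gives > 10000 nM in this assay, again a limit. The step that the two limits leave unreadable from compound 1 to compound 2 is therefore unreadable, because of the limit of > 10000 nM in this assay, at which 2 of the 2 values shown sit. Compound 3 `COc1ccc(-c2cnc(C(=O)CCCCCCc3ccccc3)o2)cc1` differs from compound 2 by methoxy in place of fluoro on an aromatic carbon. Going by the values given here, no measured step touches this change; the one recorded step sits at another place and has no readable size. Compound 3 is expected to stay near the limit, with an estimated value of 15000 nM (range 5000 nM to 50000 nM), so the expected step that the limit leaves unreadable from compound 2 to compound 3 is none beyond the scatter.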

Compound 3, half-maximal inhibitory concentration: > 10000 nM
Compound 3 gave a limit, no number (the forecaster's own chance of this, stated with the estimate: 80%); the middle value is on the limit's open side.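

No step can be read among compound 1, compound 2 and compound 3, since all three give only a limit: the limit of > 10000 nM in this assay, at which 3 of the 3 values shown sit.
Left open is whether dimethylcarbamoyl, 4-fluorophenyl and 4-methoxyphenyl differ at all in this assay on the shared core.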